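The source may hold more compounds than are shown below. What is called first, only, known or untested is meant among the compounds shown, and "the series" means these compounds.

Measured so far:
Compound 1 `COCCOc1ccc2c(C(=O)NCC3CCC(F)(F)CC3)c(Cl)ccc2n1`: in an assay for antagonist activity at P2X purinoceptor 7 (Homo sapiens), read by ELISA, with a stated time of 30 min (a lower number here means a stronger inhibitor, a higher number a weaker inhibitor), compound 1 gives 140 nM
Compound 2 `O=C(NCC1CCC(F)(F)CC1)c1c(Cl)ccc2ncccc12`: in this assay compound 2 gives 220 nM

Compound 2 stands at the top of these two numbers, yet its gap to compound 1, a 1.6-fold higher number from compound 1 to compound 2 (0.20 log units; within the scatter), is within the scatter. Compound 3 `O=C(NCC1CCC(F)(F)CC1)c1c(Cl)ccc2nc(C3=CCCC3)ccc12` differs from compound 2 by cyclopent-1-en-1-yl in place of hydrogen on an aromatic carbon. Among the measured compounds shown here, the only step that bears on this position is a 1.6-fold higher number from compound 1 to compound 2 (0.20 log units; within the scatter), which shows that a group at this place is at least tolerated. A step of a 2.2-fold lower number from compound 2 to compound 3 (0.34 log units; beyond the scatter) toward a lower number is therefore expected, with real uncertainty. Compound 3 is estimated at 100 nM in this assay, with a range from 30 nM to 400 nM.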

Compound 3, half-maximal inhibitory concentration: 90 nM
Estimate against measurement, compound 3: 1.1-fold (0.05 log units) above; the measured number falls inside the stated range.
By their numbers in this assay, from the lowest: compounds 3, 1 and 2 (each within the scatter of the next, the first and the last beyond it).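

Among the compounds shown here, with cyclopent-1-en-1-yl next to the ring nitrogen, the change from hydrogen gives a 2.4-fold lower number from compound 2 to compound 3 (0.39 log units; beyond the scatter) in this assay, the first step at this position that clears the scatter. Replacing 2-methoxyethoxy with the same ring gives a 1.6-fold lower number from compound 1 to compound 3 (0.19 log units; within the scatter) and so does not separate these two groups, even though the ring has only carbon atoms. No available evidence explains either step. From the compounds shown here alone, it remains open how an amine, a saturated cyclopentyl ring or a longer carbon chain at this position would compare.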